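Swapping the sulfonyl aryl group on a shared ketone-piperidine core

This account rests on a few compounds, and the source may have more. Where it says the series, first, only, none or still open, it means among the compounds named here.

Three compounds sharing one core were compared in an assay on HEK293 cells for displacement of a labelled ligand from 5-hydroxytryptamine receptor 6 (Homo sapiens), with a stated time of 60 min, tested at 1 uM, in the presence of a further agent that is not named here; on this read-out lower numbers stand for a weaker effect and higher numbers for a stronger effect at the one concentration tested. Compound 1 `COc1cc(N)c(Cl)cc1C(=O)CCC1CCN(CCNS(=O)(=O)c2ccc(N)cc2)CC1` gives 46% and stands second highest of the three numbers. Compound 3 `COc1cc(N)c(Cl)cc1C(=O)CCC1CCN(CCNS(=O)(=O)c2cc(Br)ccc2Br)CC1` gives 52%, and the step of a number 6 percentage points higher from compound 1 to compound 3 (within the scatter) lies within the scatter. Compound 2 `COc1cc(N)c(Cl)cc1C(=O)CCC1CCN(CCNS(=O)(=O)c2ccc(C)cc2)CC1` gives 15%, and the step of a number 31 percentage points lower from compound 1 to compound 2 (beyond the scatter) is large, as is a number 37 percentage points higher from compound 2 to compound 3 (beyond the scatter).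

Compound 4 `COc1ccc(S(=O)(=O)NCCN2CCC(CCC(=O)c3cc(Cl)c(N)cc3OC)CC2)c(OC)c1` has not yet been measured. It differs from compound 1 in one place: 2,4-dimethoxyphenyl in place of 4-aminophenyl on a sulfonyl sulfur

Among the measured compounds shown here, two measured steps bear on this change. Replacing the aryl group on the sulfonyl sulfur by 2,5-dibromophenyl, in the step from compound 1 to compound 3, changed this assay by no more than the scatter. Exchanging the amino for methyl on the aromatic carbon, in the step from compound 1 to compound 2, lowered this assay by a large amount. Compound 4 likewise loses the amino group, yet compound 3 shows that an aryl group without that amino can match compound 1. A modest downward step is therefore expected, a number 10 percentage points lower from compound 1 to compound 4 (within the scatter), with wide uncertainty. Compound 4 is estimated to give 36% in this assay, within a range from 12% to 60%.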

Compound 4, a percentage reported as inhibition, at one concentration (the size of the read-out at that concentration, not a potency): 45%
For compound 4 the middle estimate is 9 percentage points below the measured one, within the range that was stated.
By their numbers in this assay, from the lowest: compound 2; then compounds 4, 1 and 3 (each within the scatter of the next).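

With 2,4-dimethoxyphenyl on the sulfonyl sulfur, the step of a number 1 percentage points lower from compound 1 to compound 4 (within the scatter) shows that a second aryl group without the amino group, this one with 10 heavy atoms, 0 hydrogen-bond donors and 2 hydrogen-bond acceptors, stays level with the 4-aminophenyl group of compound 1 in this assay. The step of a number 7 percentage points lower from compound 3 to compound 4 (within the scatter) also leaves it level with the 2,5-dibromophenyl group, so three different aryl groups now give numbers within the scatter of one another. Compound 2 goes against that grouping, and the step of a number 30 percentage points higher from compound 2 to compound 4 (beyond the scatter) confirms that, among the four compounds, the 4-methylphenyl group alone stands apart, so losing the amino group does not by itself bring the number down.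

On these data alone, it remains open where a plain phenyl or a 4-methoxyphenyl group on the sulfonyl sulfur would fall, and so whether the low number of compound 2 belongs to the 4-methylphenyl group alone or is shared by other aryl groups. Nothing given here explains why the 4-methylphenyl group differs from the other three.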